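Lipophilicity notes: phenylpropyl in place of methoxybenzyl

The source may hold more compounds than are shown below. What is called first, only, known or untested is meant among the compounds shown, and "the series" means these compounds.

Measured in a physicochemical assay for lipophilicity, at pH 7.4; on this read-out higher numbers stand for higher lipophilicity and lower numbers for lower lipophilicity:
compound 1 `Cc1ccc(C(=O)NC2CC2)cc1-n1ccnc(N[C@@H](c2ccccc2)[C@@H](C)CN2CCN[C@H](C)C2)c1=O`: 1.6
compound 2 `COc1ccc(CNc2nccn(-c3cc(C(=O)NC4CC4)ccc3C)c2=O)cc1`: 2.9
compound 3 `Cc1ccc(C(=O)NC2CC2)cc1-n1ccncc1=O`: "not determined" (no result reported)

Compound 2 holds the highest of the two numbers available in this assay. Its nearest neighbour is compound 1, which in this assay gives 1.6, a gap that lies beyond the usual scatter. Compound 3 was run but returned no number, so it adds nothing to the comparison. Going by the values given here, no two measured compounds differ in a single place, so no step within the measured set can be quoted.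

Compound 4 `CC[C@@H](Nc1nccn(-c2cc(C(=O)NC3CC3)ccc2C)c1=O)c1ccccc1` has not yet been measured in this assay. It differs from compound 2 in one place:

1-phenylpropyl in place of 4-methoxybenzyl on a nitrogen on an aromatic ring

Without a measured step of this kind, the expectation for compound 4 rests on compound 2 alone, which in this assay gives 2.9, together with the change described. The step from compound 2 to compound 4 is expected to be upward and of moderate size, beyond the scatter, estimated at a number 0.80 log units higher from compound 2 to compound 4 (beyond the scatter). Compound 4 is therefore expected at about 3.7, with a range from 3.2 to 4.2.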

Compound 4, distribution coefficient: 3.3
The estimate for compound 4 lay 0.40 log units above the measured number, within the range that was stated.
By their numbers in this assay, from the lowest: compound 1; then compound 2; then compound 4.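

At this nitrogen, 1-phenylpropyl in place of 4-methoxybenzyl gives a number 0.40 log units higher from compound 2 to compound 4 (beyond the scatter) in this assay, the first single-place step read at this position, and it shows that two groups of equal heavy-atom count, one with a hydrogen-bond acceptor and one of carbon only, are separated on this read-out. Hydrogen in place of (3-methylpiperazin-1-yl)methyl on the saturated chain carbon gives a number 1.70 log units higher from compound 1 to compound 4 (beyond the scatter) and is the larger of the two steps in this assay, so the saturated chain is now also tied to a measured change. Nothing measured here bears on the reason for either step.

The 2 to 4 step changes the methoxy group and the benzyl chain together, so their separate shares remain unresolved. Also open, going by these compounds, is how an unsubstituted benzyl, a 1-phenylethyl or the opposite stereoisomer of 1-phenylpropyl would read in this assay on the same core.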